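The compounds below may be only part of what the source reports. "The series", "measured", "known", "first", "only" and "open" are said of these compounds alone.

In a toxicity assay on L02 cells (Homo sapiens) for cytotoxicity, read by MTT assay, with a stated time of 72 h (a higher number here means a weaker inhibitor, a lower number a stronger inhibitor), three compounds sharing one core have numbers: compound 1 `CN(C)CCCCCn1c2c(c3ccccc31)C(=O)c1c[n+]([O-])c3ccccc3c1C2=O` gives 240 nM, compound 2 `O=C1c2c[n+]([O-])c3ccccc3c2C(=O)c2c1c1ccccc1n2CCN1CCCC1` gives 930 nM, and compound 3 `O=C1c2c[n+]([O-])c3ccccc3c2C(=O)c2c1c1ccccc1n2CCCCN1CCNCC1` gives 1380 nM. That last number has one close neighbour and one distant one: a 1.5-fold higher number from compound 2 to compound 3 (0.17 log units; within the scatter), but a 5.8-fold higher number from compound 1 to compound 3 (0.76 log units; beyond the scatter). Compound 4 `CCCCN1CCN(CCCCn2c3c(c4ccccc42)C(=O)c2c[n+]([O-])c4ccccc4c2C3=O)CC1` carries butyl in place of hydrogen on an amine nitrogen in a ring, butyl in place of hydrogen on an amine nitrogen in a ring. Going by the values given here, no measured step makes this change. The nearest guides alter the amine end and the chain together, and they are at most modest: a 3.9-fold higher number from compound 1 to compound 2 (0.59 log units; beyond the scatter) and a 5.8-fold higher number from compound 1 to compound 3 (0.76 log units; beyond the scatter). A slight lean to a lower number therefore rests on a 5.8-fold higher number from compound 1 to compound 3 (0.76 log units; beyond the scatter) alone, while a 1.5-fold higher number from compound 2 to compound 3 (0.17 log units; within the scatter) offers none. The expected step is a 1.5-fold lower number from compound 3 to compound 4 (0.19 log units; within the scatter), small and probably within the scatter. Compound 4 is estimated at 900 nM, with an expected range of 300 nM to 2700 nM.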

Compound 4, half-maximal inhibitory concentration: 5690 nM
Estimate against measurement, compound 4: 6.3-fold (0.80 log units) below, outside the stated range (above it).
By their numbers in this assay, from the lowest: compound 1; then compounds 2 and 3 (each within the scatter of the next); then compound 4.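

In this assay, going by these compounds alone, butyl in place of hydrogen on an amine nitrogen in a ring gives a 4.1-fold higher number from compound 3 to compound 4 (0.62 log units; beyond the scatter), the first single change at this position, and it shows that the number here responds to substitution on that nitrogen. Within the data shown here, the same group also sets the compound apart from the others, with a 6.1-fold higher number from compound 2 to compound 4 (0.79 log units; beyond the scatter) and a 24-fold higher number from compound 1 to compound 4 (1.37 log units; beyond the scatter), the last being the only large step so far. Nothing shown here accounts for this rise. Going by these compounds, whether a smaller methyl, a longer octyl chain or an acetyl group on that nitrogen would move the number the same way remains open.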